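A few compounds are considered here, and "the series" means these few. Any claim that something is new, unique, unknown or untested is made for them only; others in the source may bear on it.

Measured so far in an assay on isolated protein for inhibition of Retinaldehyde dehydrogenase 3 (Homo sapiens); on this read-out lower numbers stand for stronger inhibition and higher numbers for weaker inhibition:
- compound 1 `CC(Sc1nc2c(cnn2C)c(=O)n1-c1ccc(CO)cc1)c1ccccc1`: 1000 nM
- compound 2 `CC(Sc1nc2nn(C3COC3)cc2c(=O)n1-c1ccccc1)c1cccnc1`: 250 nM
- compound 3 `CC(Sc1nc2nn(C3COC3)cc2c(=O)n1-c1ccccc1)c1ccccc1`: 109 nM

Compound 1 stands highest of the three numbers in this assay, with compound 2 and compound 3 both lower and beyond the scatter. Among the compounds with values here, the only single-place step measured is a 2.3-fold lower number from compound 2 to compound 3 (0.36 log units; beyond the scatter), a modest change on the chain carbon and not on the aryl ring bound to the core nitrogen.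

Compound 4 `CC(Sc1nc2c(cnn2C)c(=O)n1-c1ccccc1)c1ccccc1` differs from compound 1 by hydrogen in place of hydroxymethyl on an aromatic carbon. Within the data shown here, no measured pair carries this change, so the step in this assay cannot be read from the data; any direction is open, and a step within the scatter is as plausible as one beyond it. Compound 4 is therefore estimated at 700 nM, with a range of 200 nM to 2500 nM, which would mean an expected step of a 1.4-fold lower number from compound 1 to compound 4 (0.15 log units; within the scatter).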

Compound 4, half-maximal inhibitory concentration: 73 nM
Compound 4: the middle estimate sits 9.6-fold (0.98 log units) above what was measured; the whole stated range lies above it.
By their numbers in this assay, from the lowest: compounds 4 and 3 (each within the scatter of the next); then compound 2; then compound 1.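

In this assay, the change from 4-(hydroxymethyl)phenyl to phenyl gives a 14-fold lower number from compound 1 to compound 4 (1.14 log units; beyond the scatter), a large step that shows this place on the aromatic ring can move the number strongly. Here, the hydroxymethyl group goes with weaker inhibition, though this rests on one pair only. Nothing at hand explains the size of this step.

From the compounds shown here alone, whether a methoxy group, a fluorine, an amine or a carboxylic acid at this place would match the hydrogen of compound 4 stays open. So does whether the same change carries the same step with the substituents of compound 3.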